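The source may report more compounds than this note shows. Statements on the series, on what has been measured and on what is new or still open speak of the compounds shown alone.

Compound 1 `Cc1ccccc1-c1cncc(OC[C@@H]2CCCN2C)c1` gives the highest number of the three measured in an assay on membranes from brain for binding affinity to Neuronal acetylcholine receptor; alpha4/beta2 (Rattus norvegicus) (on this read-out higher numbers stand for weaker inhibition and lower numbers for stronger inhibition), at 1.1 nM. Compound 2 `CN1CCC[C@H]1COc1cncc(-c2ccccc2C=O)c1` gives 0.56 nM, and compound 3 `CN1CCC[C@H]1COc1cncc(-c2cc3ccccc3n2C)c1` gives 0.32 nM. The step of a 2.0-fold lower number from compound 1 to compound 2 (0.29 log units; within the scatter) stays within the scatter, while the gap from compound 1 to compound 3 lies beyond it. Compound 4 `CN1CCC[C@H]1COc1cncc(-c2ccco2)c1` alters the core of compound 1 by furan-2-yl in place of 2-methylphenyl on an aromatic carbon. Among the measured compounds shown here, the one measured step changes only a substituent on the 2-methylphenyl ring, so it says little about exchanging that ring for a five-membered furan-2-yl; still, all three measured compounds carrying an aromatic group at this place give low numbers in this assay. Compound 4 is therefore expected to show a 1.2-fold lower number from compound 1 to compound 4 (0.09 log units; within the scatter), with no clear direction beyond the scatter, and an estimated value of 0.9 nM between 0.25 nM and 3.5 nM.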

Compound 4, inhibition constant: 0.19 nM
Compound 4: middle estimate off by 4.7-fold (0.68 log units), on the high side; the whole stated range lies above it.
By their numbers in this assay, from the lowest: compounds 4, 3, 2 and 1 (each within the scatter of the next, the first and the last beyond it).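

At this place on the pyridine-type ring, this assay accepts a five-membered aromatic ring as well as a six-membered one: furan-2-yl in place of 2-methylphenyl gives a 5.8-fold lower number from compound 1 to compound 4 (0.76 log units; beyond the scatter). The change alters ring size, removes the methyl group and brings in a ring oxygen all at once, so this single step cannot separate their contributions. No available evidence explains the lower number. Still open, on these data alone, is whether thiophen-2-yl, with sulfur in place of the oxygen, or unsubstituted phenyl would give a similar number. A non-aromatic group such as cyclopentyl at this place also remains untested in the compounds shown.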